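Iodo on the Core: Weak Antiproliferative Series Extended

A few compounds are considered here, and "the series" means these few. Any claim that something is new, unique, unknown or untested is made for them only; others in the source may bear on it.

Compound 1, with structure `COc1ccc(-c2cc(=O)c3c(OC)cc(OC)cc3[nH]2)cc1`, is the starting point. In an ADME assay on BJ cells (Homo sapiens) for antiproliferative activity, with a stated time of 72 h (on this read-out lower numbers stand for an effect already at smaller amounts and higher numbers for an effect only at larger amounts of compound), compound 1 gives only a limit of the assay, > 62000 nM, not a number. Two other compounds carry changes on the ring nitrogen of the same core. Compound 2, `COc1ccc(-c2cc(=O)c3c(OC)cc(OC)cc3n2Cc2ccccc2)cc1`, has a benzyl in place of hydrogen there; in this assay compound 2 also reaches only the limit > 34400 nM. Compound 3, `C=CCNC(=O)n1c(-c2ccc(OC)cc2)cc(=O)c2c(OC)cc(OC)cc21`, has an allylcarbamoyl in that place and in this assay compound 3 gives 74000 nM. Because the values sit at the limit of > 62000 nM in this assay, at which 1 of the 3 values shown sits, and (the limit of > 34400 nM in this assay, at which 1 of the 3 values shown sits), the steps a step that the two limits leave unreadable from compound 1 to compound 2, a step that the limit leaves unreadable from compound 1 to compound 3 and a step that the limit leaves unreadable from compound 2 to compound 3 cannot be sized. Compound 4, `COc1ccc(-c2[nH]c3cc(OC)cc(OC)c3c(=O)c2I)cc1`, differs from compound 1 by iodo in place of hydrogen on an aromatic carbon. Among the compounds with values here, no measured step touches an aromatic carbon, so none of them bears on this change, and the three measured compounds all stand at or beyond the limits. Compound 4 is therefore expected to stay in that weak region, with a step of an at least 1.0-fold lower number from compound 1 to compound 4 (0.01 log units; that floor lies within the scatter) that is not expected to exceed the scatter. The estimate for compound 4 in this assay is 60000 nM, within 20000 nM to 150000 nM.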

Compound 4, half-maximal effective concentration: > 86200 nM
Compound 4: a limit, no number; the forecaster's own chance of this, stated with the estimate: 60%; middle value at least 1.4-fold (0.15 log units) from the limit.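

Compound 1 and compound 4 each give only a limit in this assay, not a number, so the step between them cannot be read. The compounds shown leave open whether iodo in place of hydrogen on an aromatic carbon changes the antiproliferative effect at all.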